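The compounds below may be only part of what the source reports. "The series", "measured", "known", "first", "only" and "open" are said of these compounds alone.

Measured compounds in a functional assay on U-937 cells (Homo sapiens) for cytotoxicity, read by MTT assay, with a stated time of 24 h; on this read-out lower numbers stand for stronger inhibition and higher numbers for weaker inhibition:
compound 1 `CCCCCCCCCCn1cc(-c2nc3ccccc3cc2CCC)nn1` — 26.6 ug/mL
compound 2 `CCCCCCCCCCn1cc(-c2nc3ccccc3cc2CCCCC)nn1` — 18.2 ug/mL
compound 3 `CCc1cc2ccccc2nc1-c1cn(-c2ccc(F)cc2)nn1` — a limit, > 100 ug/mL

Compound 3 gives only a limit in this assay; that value the limit of > 100 ug/mL in this assay, at which 1 of the 3 values shown sits, is not a number and is set aside in what follows. Among the two numbers, compound 2 has the lower one, with compound 1 nearest to it: the step of a 1.5-fold lower number from compound 1 to compound 2 (0.16 log units; within the scatter) is within the scatter, so the two cannot be ordered.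

Compound 4 `CCCCCCCCCCn1cc(-c2nc3ccccc3cc2CCCC)nn1` is not yet measured in this assay. It differs from compound 2 in one place: hydrogen in place of methyl on a saturated chain carbon, four bonds along the chain from an aromatic carbon. Going by the values given here, the only measured step that bears on this place is the one from propyl to pentyl on the shared core, a 1.5-fold lower number from compound 1 to compound 2 (0.16 log units; within the scatter), which was within the scatter; compound 4 carries the butyl chain that lies between those two. No step beyond the scatter is therefore expected for a 1.2-fold higher number from compound 2 to compound 4 (0.08 log units; within the scatter), in either direction.

Compound 4 is estimated at 22 ug/mL in this assay, with a range from 12 ug/mL to 40 ug/mL.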

Compound 4, half-maximal inhibitory concentration: 25.2 ug/mL
Compound 4: middle estimate off by 1.1-fold (0.06 log units), on the low side; the range from low to high includes it.
By their numbers in this assay, from the lowest: compounds 2, 4 and 1 (each within the scatter of the next). At a limit, above all of these: compound 3.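

In this assay, the butyl chain of compound 4 fills the gap between propyl and pentyl on the shared core, and both new steps are small: a 1.4-fold higher number from compound 2 to compound 4 (0.14 log units; within the scatter), and a 1.1-fold lower number from compound 1 to compound 4 (0.02 log units; within the scatter). Compounds 1 and 2 alone offered a single step, whereas three chain lengths now lie within the scatter of one another, so methyl in place of hydrogen at the end of this chain does not separate these compounds and no trend with chain length can be read from propyl through pentyl. Nothing shown gives a cause for these small steps.

As far as these compounds go, whether a longer chain such as octyl, a shorter one such as methyl, or a chain ending in an amine or a carboxylic acid would move the number beyond the scatter stays open. From the compounds shown here alone, compound 3 gives only a limit, > 100 ug/mL, and differs from the chain series in more than one place, so the part played by the decyl group shared by compound 1, compound 2 and compound 4 also stays open.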